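Methoxymethyl to acetoxymethyl: an estimate for cytotoxicity

This account rests on a few compounds, and the source may have more. Where it says the series, first, only, none or still open, it means among the compounds named here.

Measured compounds:
compound 1, `COCc1c(C)coc1-c1ccc2c(c1OC)CCCC2(C)C`, in a functional assay on A549 cells (Homo sapiens) for cytotoxicity, read by sulforhodamine B assay, with a stated time of 3 days (a lower number here means that less compound is needed, a higher number that more compound is needed for the effect), gives 19.4 uM
compound 2, `Cc1coc(-c2ccc3c(c2O)CCCC3)c1C(=O)O`, in this assay gives 57 uM

Two compounds carry numbers in this assay. Compound 1 stands lowest of the two; its nearest neighbour is compound 2, whose number is higher by a margin beyond the usual scatter. For the measured compounds named here, no pair of these two differs in only one place, so no single change has a known effect here, and the pair shows only that compound 1 needs less material than compound 2 for the same effect.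

Compound 3, `COc1c(-c2occ(C)c2COC(C)=O)ccc2c1CCCC2(C)C`, is not yet measured. It differs from compound 1 by acetyl in place of methyl on an oxygen on a saturated carbon; read one bond further out, methoxymethyl becomes acetoxymethyl. Going by the values given here, nothing among the measured compounds tests this change, so any expectation rests on the size of the alteration, which is modest. Compound 3 is expected to give 16 uM, with a range from 6 uM to 45 uM. The step of a 1.2-fold lower number from compound 1 to compound 3 (0.08 log units; within the scatter) is accordingly estimated to be small, probably within the scatter, with no confident direction.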

Compound 3, concentration for half-maximal effect: 28.7 uM
Compound 3: the middle estimate sits 1.8-fold (0.25 log units) below what was measured; measured number inside the range.
By their numbers in this assay, from the lowest: compounds 1, 3 and 2 (each within the scatter of the next, the first and the last beyond it).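

For the compounds shown here, exchanging methyl for acetyl on the oxygen on a saturated carbon, which turns methoxymethyl into acetoxymethyl, gives the first single-place comparison in this assay: a 1.5-fold higher number from compound 1 to compound 3 (0.17 log units; within the scatter). At this position, therefore, the two groups cannot be told apart in this assay, even though the entering acetyl has 3 heavy atoms where the leaving methyl has 1, and brings a hydrogen-bond acceptor and a double bond outside aromatic rings. There is no evidence here that explains this result.

The compounds shown leave open whether a free hydroxymethyl, an aminomethyl or an ester with a longer chain, such as butanoyloxymethyl, would also stay within the scatter of compound 1 at this position. They also leave open which of the several differences between compound 2 and the other two compounds accounts for its position in the series, since compound 2 is not separated from either of them by a single change.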